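The compounds below may be only part of what the source reports. "The series", "measured", "known", "first", "only" and "open" are said of these compounds alone.

Working notes on the series in a functional assay on K562 cells (Homo sapiens) for antiproliferative activity, read by sulforhodamine B assay, with a stated time of 72 h; a higher number here means a weaker inhibitor, a lower number a stronger inhibitor. Compound 1 (`O=S(=O)(Nc1ncccn1)c1ccc(Nc2nncc3ccccc23)cc1`) gives 43 nM, compound 2 (`Fc1ccc(Nc2nncc3ccccc23)cc1`) gives 6.7 nM and compound 3 (`NS(=O)(=O)c1ccc(Nc2nncc3ccccc23)cc1`) gives 14 nM, the middle of the three numbers. Compound 4 (`N#Cc1ccc(Nc2nncc3ccccc23)cc1`) is unmeasured and has cyano in place of sulfamoyl on an aromatic carbon, para to a large group: cyano in place of sulfamoyl on an aromatic carbon. The closest measured change is a 2.1-fold higher number from compound 2 to compound 3 (0.32 log units; beyond the scatter), which swaps fluoro for sulfamoyl at that carbon. The step of a 3.1-fold lower number from compound 1 to compound 3 (0.49 log units; beyond the scatter) concerns the sulfonamide nitrogen and bears only loosely. Among the measured compounds shown here, no measured compound carries cyano, so only a small shift toward a lower number is expected, probably within the scatter. The expected step is a 1.6-fold lower number from compound 3 to compound 4 (0.19 log units; within the scatter). For compound 4 the estimated value is 9 nM, with an expected range of 3 nM to 28 nM.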

Compound 4, half-maximal inhibitory concentration: 2.6 nM
Compound 4: the middle estimate sits 3.5-fold (0.54 log units) above what was measured; measured number below the stated range.
By their numbers in this assay, from the lowest: compound 4; then compound 2; then compound 3; then compound 1.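

Replacing sulfamoyl with cyano at this aromatic carbon gives a 5.4-fold lower number from compound 3 to compound 4 (0.73 log units; beyond the scatter) and replacing fluoro with cyano gives a 2.6-fold lower number from compound 2 to compound 4 (0.41 log units; beyond the scatter) so the new group separates from both earlier ones beyond the scatter. The earlier compounds shown here ranked only fluoro and sulfamoyl here; the order from the lowest number now runs cyano, fluoro, sulfamoyl across three groups on the same core. On these data alone, whether an amine, a carboxylic acid or a methoxy group at this carbon would fall inside or outside that order stays open. No supporting data explain why cyano gives the lowest number of the three.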